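The source may report more compounds than this note shows. Statements on the series, on what has been measured and on what is new or still open speak of the compounds shown alone.

Three compounds share one core and differ only in the group on an aromatic carbon. Compound 1 `O=S(=O)(c1ccc([C@H]2CC[C@]3(CC2)OOC2(O3)C3CC4CC(C3)CC2C4)cc1)N1CCNCC1` gives in an ADME assay on microsomes from liver (Homo sapiens) for metabolic stability, read by LC-MS, tested at 1 uM (a lower number here means slower removal, a higher number faster removal of the compound), a value of 16 mL.min-1.g-1. Compound 3 `CC(C)(O)CNCCCOc1ccc([C@H]2CC[C@]3(CC2)OOC2(O3)C3CC4CC(C3)CC2C4)cc1` gives in this assay 8 mL.min-1.g-1. Compound 2 `NCCOc1ccc([C@H]2CC[C@]3(CC2)OOC2(O3)C3CC4CC(C3)CC2C4)cc1` returns in this assay a result of < 7 mL.min-1.g-1, which is a limit of the assay and not a number. Compound 2 therefore stands at the limit of < 7 mL.min-1.g-1 in this assay, at which 1 of the 3 values shown sits.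

The measured steps are an at least 2.2-fold lower number from compound 1 to compound 2 (0.35 log units; beyond the scatter), a 2.0-fold lower number from compound 1 to compound 3 (0.30 log units; within the scatter) and an at least 1.1-fold higher number from compound 2 to compound 3 (0.05 log units; that floor lies within the scatter).

Compound 4 `NCCCCOc1ccc([C@H]2CC[C@]3(CC2)OOC2(O3)C3CC4CC(C3)CC2C4)cc1` differs from compound 2 by 2-aminoethyl in place of amino on a saturated chain carbon, two bonds along the chain from an oxygen on an aromatic ring. Among the compounds with values here, the step that bears most directly on it is the one from compound 2 to compound 3, an at least 1.1-fold higher number from compound 2 to compound 3 (0.05 log units; that floor lies within the scatter), which changes the same chain carbon by a larger group than the one entering here and stays within the scatter. Compound 4 is therefore expected to show a number no lower from compound 2 to compound 4 (the limit leaves the size open), with no step beyond the scatter. The estimate for compound 4 in this assay is 7 mL.min-1.g-1, expected to fall between 4 mL.min-1.g-1 and 14 mL.min-1.g-1.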

Compound 4, intrinsic clearance in microsomes: < 7 mL.min-1.g-1
Compound 4 was reported as a limit; the forecaster's own chance of this, stated with the estimate: 50%; the middle value lies on the limit itself.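

In this assay compound 4 gives < 7 mL.min-1.g-1, which is a limit of the assay and not a number. The step between compound 2 and compound 4 cannot be read because both results are limits, so the 2-aminoethyl change shows only that the primary amine chain can be extended from 2-aminoethoxy to 4-aminobutoxy with the result still at the limit: the limit of < 7 mL.min-1.g-1 in this assay, at which 2 of the 4 values shown sit. The result is also an at least 2.2-fold lower number from compound 1 to compound 4 (0.35 log units; beyond the scatter), which extends the drop seen with compound 2 to a second chain, whereas the result is an at least 1.1-fold lower number from compound 3 to compound 4 (0.05 log units; that floor lies within the scatter), so no order is established there.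

From the compounds shown here alone, how far compound 2 and compound 4 lie under the limit remains open, and with it any effect of chain length on the number itself. Going by these compounds, whether a longer chain or a carboxylic acid in place of the amine would stay at the limit also remains open.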